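A few compounds are considered here, and "the series" means these few. Any claim that something is new, unique, unknown or untested is made for them only; others in the source may bear on it.

Measured so far in an assay on Sf9 cells for inhibition of protein deacetylase HDAC6 (Homo sapiens), read by fluorescence, with a stated time of 40 min, tested at 100 nM; a lower number here means less inhibition, a higher number more inhibition at the concentration tested (going by the name of the read-out):
compound 1, `COc1ccc(-n2nc(-c3ccccc3)nc2CNc2ccc(C(=O)NO)cc2)cc1`: 63.4%
compound 2, `O=C(NO)c1ccc(NCc2nc(-c3ccc(Br)cc3)nn2-c2ccccc2)cc1`: 54.7%
compound 3, `O=C(NO)c1ccc(NCc2nc(-c3ccccc3)nn2-c2ccc(Cl)cc2)cc1`: 55.4%

Compound 2 gives the lowest of the three numbers, yet its gap to compound 3 and its gap to compound 1 both lie within the scatter, so no order among the three can be read. For the measured compounds named here, the only single-change step measured, a number 8 percentage points lower from compound 1 to compound 3 (within the scatter), is within the scatter. Compound 4, `Cc1ccc(-c2nc(CNc3ccc(C(=O)NO)cc3)n(-c3ccccc3)n2)o1`, differs from compound 2 in one place: 5-methylfuran-2-yl in place of 4-bromophenyl on an aromatic carbon. Going by the values given here, no measured step exchanges the 4-bromophenyl group for a five-membered ring, so the step from compound 1 to compound 3 bears on it only loosely, as the sole example of a change on an aromatic carbon, and that change stayed within the scatter. A step within the scatter is therefore expected, a number 0.3 percentage points higher from compound 2 to compound 4 (within the scatter). Compound 4 is estimated at 55%, between 40% and 70%.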

Compound 4, a percentage reported as inhibition, at one concentration (the size of the read-out at that concentration, not a potency): 60.7%
Estimate against measurement, compound 4: 5.7 percentage points below; the range from low to high includes it.
By their numbers in this assay, from the lowest: compounds 2, 3, 4 and 1 (each within the scatter of the next).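

The step in this assay on the aromatic carbon between two ring nitrogen atoms is a number 6 percentage points higher from compound 2 to compound 4 (within the scatter) with 5-methylfuran-2-yl in place of 4-bromophenyl. This position therefore carries a five-membered aromatic ring with 1 hetero atom as well as a six-membered aromatic ring of carbon only, without a change that can be read. Nothing measured here speaks to the reason for this result.

Open, as far as these compounds go, is whether a group without an aromatic ring at this carbon, such as an amine, a carboxylic acid or a longer alkyl chain, would stay within the scatter. Also open, from the compounds shown here alone, is whether an unsubstituted furan-2-yl would do the same.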